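A Longer Chain on the Amide Nitrogen

A few compounds are considered here, and "the series" means these few. Any claim that something is new, unique, unknown or untested is made for them only; others in the source may bear on it.

Of the compounds shown here, two have been measured in an assay on HEK293 cells for agonist activity at transient receptor potential cation channel subfamily M member 8 (Homo sapiens), read by fluorescence and calcium flux, with a stated time of 15 min; a lower number here means that less compound is needed, a higher number that more compound is needed for the effect. Compound 1, `CCN(Cc1cccs1)C(=O)COc1ccc(Cl)cc1`, gives 39 nM in this assay. Compound 2, `Cc1ccc(OCC(=O)N(C)Cc2cccs2)cc1`, gives 400 nM in this assay, the higher of the two numbers, and compound 1 stands well below it, beyond the scatter. For the measured compounds named here, compound 1 and compound 2 differ in two places at once, so no single step connects them.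

Compound 3, `CCCN(Cc1cccs1)C(=O)COc1ccc(C)cc1`, has not yet been measured. It differs from compound 2 by ethyl in place of hydrogen on a saturated chain carbon bound to an amide-type nitrogen. Compound 1 carries an ethyl on the same nitrogen together with a different ring substituent, so its lower number cannot be assigned to the chain alone. A modest decrease in this assay is expected, not a large one. Compound 3 is expected to give 200 nM, within 60 nM to 700 nM. The step of a 2.0-fold lower number from compound 2 to compound 3 (0.30 log units; within the scatter) is expected to lie near the edge of the scatter.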

Compound 3, half-maximal effective concentration: 40 nM
Compound 3: middle estimate off by 5.0-fold (0.70 log units), on the high side; measured number outside the range, below it.
By their numbers in this assay, from the lowest: compounds 1 and 3 (each within the scatter of the next); then compound 2.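

For the compounds shown here, compound 2 and compound 3 differ in one place only, so this pair isolates the chain on the amide nitrogen, which the earlier compounds could not do. In this assay, ethyl in place of hydrogen on a saturated chain carbon bound to an amide-type nitrogen gives a 10-fold lower number from compound 2 to compound 3 (1.00 log units; beyond the scatter). The change from methyl to propyl is thus enough on its own to shift the number, with the ring substituent of compound 2 left as it stands. Nothing available here accounts for the size of this step.

The compounds shown leave open whether a longer chain such as butyl or pentyl would lower the number further or raise it again. They also leave open how a branched chain such as isopropyl, or an amine or a carboxylic acid at the end of the chain, would read at this place.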